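Replacing a methyl with dimethylamino on a fluorinated chromone

The source may hold more compounds than are shown below. What is called first, only, known or untested is meant among the compounds shown, and "the series" means these compounds.

Values in a functional assay on HeLa cells (Homo sapiens) for cytotoxicity, read by neutral red uptake, with a stated time of 3 days; a higher number here means a weaker inhibitor, a lower number a stronger inhibitor:
Compound 1, `Cc1c(F)c(N)c2c(=O)cc(-c3ccc(N)c(F)c3)oc2c1F`: > 100000 nM
Compound 2, `CCc1c(F)c(N)c2c(=O)cc(-c3ccc(N)c(F)c3)oc2c1F`: > 100000 nM
Compound 3, `CCCCCC(=O)OCc1c(F)c(N)c2c(=O)cc(-c3ccc(N)c(F)c3)oc2c1F`: 34000 nM

Compound 2 gives only a limit here, not a number: compound 2 sits at the limit of > 100000 nM in this assay, at which 2 of the 3 values shown sit. Compound 1 sits at that same limit, so a step that the two limits leave unreadable from compound 1 to compound 2 cannot be read. Compound 4, `CN(C)Cc1c(F)c(N)c2c(=O)cc(-c3ccc(N)c(F)c3)oc2c1F`, differs from compound 2 by dimethylamino in place of methyl on a saturated chain carbon bound to an aromatic carbon. Among the measured compounds shown here, no measured step introduces dimethylamino; the closest comparison is an at least 2.9-fold lower number from compound 2 to compound 3 (0.46 log units; beyond the scatter), where a larger group also enters at that same place and the number falls below the limit. A similar, modest fall is therefore expected, a step of an at least 2.0-fold lower number from compound 2 to compound 4 (0.30 log units; that floor lies within the scatter), though a limit again is possible. Compound 4 is estimated at 50000 nM, ranging from 10000 nM to 200000 nM.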

Compound 4, half-maximal inhibitory concentration: 8900 nM
Estimate against measurement, compound 4: 5.6-fold (0.75 log units) above; measured number outside the range, below it.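

In this assay, dimethylamino on the saturated chain carbon bound to an aromatic carbon gives a large change: an at least 11-fold lower number from compound 2 to compound 4 (1.05 log units; beyond the scatter) and an at least 11-fold lower number from compound 1 to compound 4 (1.05 log units; beyond the scatter). It also beats the longer (pentylcarbonyl)oxy group at that place, with a 3.8-fold lower number from compound 3 to compound 4 (0.58 log units; beyond the scatter), so the longer group does not give the lowest number among these compounds. The steps from compound 1 and compound 2 are only floors, and the step from compound 1 to compound 2 cannot be read, because both sit at a limit: the limit of > 100000 nM in this assay, at which 2 of the 4 values shown sit.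

As far as these compounds go, whether the nitrogen itself matters stays open. A primary amine, or a longer chain ending in dimethylamino, at this place would test it.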